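The source may hold more compounds than are shown below. What is called first, only, known or untested is meant among the compounds shown, and "the series" means these compounds.

Compound 1 `Nc1ccccc1NC(=O)c1ccc(CSC(=S)N2CCN(c3ccc(Cl)cc3)CC2)cc1`, compound 2 `CN1CCN(C(=S)SCc2ccc(C(=O)Nc3ccccc3N)cc2)CC1` and compound 3 `Nc1ccccc1NC(=O)c1ccc(CSC(=S)N2CCN(c3ccccc3F)CC2)cc1` share one core and differ only in the group carried on the amine nitrogen of the six-membered non-aromatic ring. In a functional assay on HeLa cells (Homo sapiens) for antiproliferative activity, read by CCK-8 assay, with a stated time of 72 h, tested at 8 uM (on this read-out higher numbers stand for a stronger effect at the one concentration tested and lower numbers for a weaker effect), compound 1 gives 44.8%, compound 2 gives 75.7%, and compound 3 gives 59.2%. Compound 3 therefore stands second highest of the three numbers: its nearest neighbour is compound 1, the step of a number 14.4 percentage points higher from compound 1 to compound 3 (beyond the scatter) being beyond the scatter, and its furthest is compound 2, the step of a number 16.5 percentage points lower from compound 2 to compound 3 (beyond the scatter) also being beyond the scatter.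

Compound 4 `Nc1ccccc1NC(=O)c1ccc(CSC(=S)N2CCN(Cc3ccccc3)CC2)cc1` has not yet been tested in this assay. It differs from compound 3 in one place: benzyl in place of 2-fluorophenyl on an amine nitrogen in a ring. Among the compounds with values here, no measured step involves benzyl, so none bears directly on this change. The steps at the same position, a number 30.9 percentage points higher from compound 1 to compound 2 (beyond the scatter) and a number 16.5 percentage points lower from compound 2 to compound 3 (beyond the scatter), show that methyl on this nitrogen gave a higher number than either aryl group, while the two aryl groups differ from each other by the modest step of a number 14.4 percentage points higher from compound 1 to compound 3 (beyond the scatter). Benzyl keeps one six-membered aromatic ring of carbon only, so for compound 4 the expected step is a number 0.8 percentage points higher from compound 3 to compound 4 (within the scatter), not beyond the scatter. Compound 4 is accordingly estimated at 60%, with a range from 42% to 76%.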

Compound 4, a percentage reported as inhibition, at one concentration (the size of the read-out at that concentration, not a potency): 31.3%
For compound 4 the middle estimate is 28.7 percentage points above the measured one; the whole stated range lies above it.
By their numbers in this assay, from the lowest: compound 4; then compound 1; then compound 3; then compound 2.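

In this assay the position proves to depend on more than the presence of one six-membered aromatic ring of carbon only: benzyl and 2-fluorophenyl each carry such a ring and the same count of heavy atoms, yet the exchange gives a number 27.9 percentage points lower from compound 3 to compound 4 (beyond the scatter) and is not a neutral swap. Benzyl in place of 4-chlorophenyl gives a number 13.5 percentage points lower from compound 1 to compound 4 (beyond the scatter) as well, so the four groups on this nitrogen now rank, from highest to lowest, as methyl, 2-fluorophenyl, 4-chlorophenyl and benzyl. Phenyl in place of hydrogen on the saturated chain carbon bound to the amine nitrogen gives a number 44.4 percentage points lower from compound 2 to compound 4 (beyond the scatter) and is the largest of these new steps, but nothing measured here accounts for any of them.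

As far as these compounds go, whether a plain ethyl, a phenethyl group or a bare hydrogen on this nitrogen would fall nearer compound 2 or compound 4 remains open. The effect of an unsubstituted phenyl also remains open, since the two aryl groups shown differ both in their halogen and in where it sits.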